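The source may report more compounds than this note shows. Statements on the series, on what has been measured and on what is new or still open speak of the compounds shown alone.

Three compounds share a common core and differ only in the aryl group attached to it. Compound 1 `CC(=O)Nc1ccc(-c2c(C)nn(-c3nc(-c4ccc(Cl)c(Cl)c4)c(SC(C)C)s3)c2C(=O)O)cc1` gives 139000 nM in a functional assay on BJAB cells (Homo sapiens) for antiproliferative activity, with a stated time of 4 days; a lower number here means that less compound is needed, a higher number that more compound is needed for the effect. Compound 2 `COc1cc(-c2c(C)nn(-c3nc(-c4ccc(Cl)c(Cl)c4)c(SC(C)C)s3)c2C(=O)O)cc(C(F)(F)F)c1` gives 1380 nM in this assay, and compound 3 `Cc1cc(C#N)cc(-c2c(C)nn(-c3nc(-c4ccc(Cl)c(Cl)c4)c(SC(C)C)s3)c2C(=O)O)c1` gives 4800 nM in this assay. Compound 3 thus stands second highest of the three, with compound 2 nearest at a 3.5-fold higher number from compound 2 to compound 3 (0.54 log units; beyond the scatter) and compound 1 furthest at a 29-fold lower number from compound 1 to compound 3 (1.46 log units; beyond the scatter).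

Compound 4 `Cc1nn(-c2nc(-c3ccc(Cl)c(Cl)c3)c(SC(C)C)s2)c(C(=O)O)c1-c1cccc(Cl)c1` differs from compound 3 as follows: 3-chlorophenyl in place of 3-cyano-5-methylphenyl on an aromatic carbon.

Going by the values given here, no measured step involves a 3-chlorophenyl group, so only indirect guidance exists. The steps of a 100-fold lower number from compound 1 to compound 2 (2.00 log units; beyond the scatter) and a 29-fold lower number from compound 1 to compound 3 (1.46 log units; beyond the scatter) show that the aryl group can shift this assay strongly, while a 3.5-fold higher number from compound 2 to compound 3 (0.54 log units; beyond the scatter) shows that exchanging one substituted phenyl for another moves it modestly. Compound 4 is therefore expected to stay in the range of compounds 2 and 3 rather than near compound 1, with a small expected step of a 1.3-fold higher number from compound 3 to compound 4 (0.10 log units; within the scatter). For compound 4 the estimated value in this assay is 6000 nM, expected between 2000 nM and 20000 nM.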

Compound 4, half-maximal effective concentration: 13600 nM
Compound 4: middle estimate off by 2.3-fold (0.36 log units), on the low side; the measured number falls inside the stated range.
By their numbers in this assay, from the lowest: compound 2; then compound 3; then compound 4; then compound 1.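

In this assay, the 3-chlorophenyl group places compound 4 in the upper middle of the set: there is a 2.8-fold higher number from compound 3 to compound 4 (0.45 log units; beyond the scatter) and a 9.9-fold higher number from compound 2 to compound 4 (0.99 log units; beyond the scatter), yet still a 10-fold lower number from compound 1 to compound 4 (1.01 log units; beyond the scatter). At this aromatic carbon, a phenyl group carrying only a chlorine therefore does not match the two groups with two substituents, 3-cyano-5-methylphenyl and 3-methoxy-5-(trifluoromethyl)phenyl, although it retains much of their gain over 4-acetamidophenyl. Nothing available explains this ranking.

The compounds shown do not separate the effect of the chlorine from that of having a single substituent, which a plain phenyl, 3-cyanophenyl or 3,5-dichlorophenyl group could address. As far as these compounds go, it also remains open whether the loss seen with 4-acetamidophenyl follows from the acetamide itself or from its place on the ring, as a 3-acetamidophenyl or 4-chlorophenyl group could show.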